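The compounds below may be only part of what the source reports. "The series", "measured", "known", "first", "only" and "open" are said of these compounds alone.

Compound 1, with the structure `C#Cc1cccc(Nc2ncnc3cc(OC)c(OCCCn4ccnc4[N+](=O)[O-])cc23)c1`, gives 5530 nM in a functional assay on HT-29 cells (Homo sapiens) for cytotoxicity, read by sulforhodamine B assay, with a stated time of 72 h; on this read-out lower numbers stand for stronger inhibition and higher numbers for weaker inhibition. Compound 2, with the structure `C#Cc1cccc(Nc2ncnc3cc(OC)c(OCCCCn4ccnc4[N+](=O)[O-])cc23)c1`, gives 6900 nM in this assay. The change between them is (2-nitro-1H-imidazol-1-yl)methyl in place of 2-nitro-1H-imidazol-1-yl on a saturated chain carbon, three bonds along the chain from an oxygen on an aromatic ring, and it made a step of a 1.2-fold higher number from compound 1 to compound 2 (0.10 log units; within the scatter). Among the compounds with values here, compound 3 has a different core, `COc1cc2ncnc(Nc3ccc(OCc4cccc(F)c4)c(Cl)c3)c2cc1OCCCn1ccnc1[N+](=O)[O-]`, and the difference between the two cores is not broken down here; in this assay compound 3 gives 20000 nM, the highest of the three numbers measured so far. Compound 4, with the structure `COc1cc2ncnc(Nc3ccc(OCc4cccc(F)c4)c(Cl)c3)c2cc1OCCCCn1ccnc1[N+](=O)[O-]`, has not yet been measured. The change from compound 3 to compound 4 is (2-nitro-1H-imidazol-1-yl)methyl in place of 2-nitro-1H-imidazol-1-yl on a saturated chain carbon, three bonds along the chain from an oxygen on an aromatic ring, the same change as that from compound 1 to compound 2, at the same place on the chain. On the core of compound 1 the added chain carbon made a step of a 1.2-fold higher number from compound 1 to compound 2 (0.10 log units; within the scatter). Within the data shown here, a step of about that size is expected from compound 3 to compound 4, a 1.2-fold higher number from compound 3 to compound 4 (0.08 log units; within the scatter), resting only on the step from compound 1 to compound 2, a 1.2-fold higher number from compound 1 to compound 2 (0.10 log units; within the scatter), since no other pair shows this change. For compound 4 the value in this assay is thus estimated at 24000 nM, expected to fall between 12000 nM and 50000 nM.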

Compound 4, half-maximal inhibitory concentration: 2070 nM
Estimate against measurement, compound 4: 12-fold (1.06 log units) above; measured number outside the range, below it.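

Moving from the 3-(2-nitro-1H-imidazol-1-yl)propyl chain to the 4-(2-nitro-1H-imidazol-1-yl)butyl chain on the core of compound 3 gave a clear gain in this assay, with a 9.7-fold lower number from compound 3 to compound 4 (0.99 log units; beyond the scatter). This single added chain carbon therefore did not behave alike on the two cores, so the step seen on one core was a poor guide to the step on the other: the same change on two cores in this assay, a 1.2-fold higher number (0.10 log units; within the scatter) from compound 1 to compound 2 and a 9.7-fold lower number (0.99 log units; beyond the scatter) from compound 3 to compound 4, 12-fold (1.08 log units) apart, beyond the scatter of two such steps

Within the data shown here, with only one pair of compounds on each core, this result does not show what about the cores produces the gap, whether it would repeat in other assays, or how the same change would behave on a third core. The compounds shown leave open how the number would move on either core with a shorter chain, such as 2-(2-nitro-1H-imidazol-1-yl)ethyl, or with a longer chain than the butyl one. They also leave open what would happen if an amine stood in place of the nitro group on the imidazole ring.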